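A few compounds are considered here, and "the series" means these few. Any claim that something is new, unique, unknown or untested is made for them only; others in the source may bear on it.

Measured so far:
- compound 1 `COc1ccc(F)cc1CNCCCNc1ccnc2cc(Cc3ccc(C#N)cc3)ccc12` — 23 10^-6 cm/s
- compound 2 `CCC(CC)c1ccc2c(NCCCNCc3cc(F)ccc3OC)ccnc2c1` — 23 10^-6 cm/s

In an ADME assay for permeability, using PAMPA, with a stated time of 30 min, at pH 7.4 (a lower number here means that the compound crosses the layer more slowly, a higher number that the compound crosses the layer faster), compound 2 gives 23 10^-6 cm/s. Compound 1 gives 23 10^-6 cm/s, and the step of no change at the digits printed from compound 1 to compound 2 (within the scatter). Among the measured compounds shown here, compound 2 therefore stands level with compound 1, and the only measured step at this position on the shared core left the read-out unchanged.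

Compound 3 `COc1ccc(F)cc1CNCCCNc1ccnc2cc(Oc3cccc(N(C)C)c3)ccc12` is the next compound, not yet measured. The change from compound 2 is 3-(dimethylamino)phenoxy in place of pentan-3-yl on an aromatic carbon. For the measured compounds named here, the one measured step that bears on it is the exchange at the same aromatic carbon, no change at the digits printed from compound 1 to compound 2 (within the scatter), which swapped one group for another without moving the read-out beyond the scatter. The incoming 3-(dimethylamino)phenoxy brings an aromatic ring and two hydrogen-bond acceptors where pentan-3-yl had none, so that step covers the present change only in part. The working expectation is a step of a 1.3-fold lower number from compound 2 to compound 3 (0.11 log units; within the scatter), at most modest and possibly none beyond the scatter. For compound 3 the estimated value in this assay is 18 10^-6 cm/s, with a range from 8 10^-6 cm/s to 35 10^-6 cm/s.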

Compound 3, apparent permeability: 317 10^-6 cm/s
Compound 3: the middle estimate sits 18-fold (1.25 log units) below what was measured, outside the stated range (above it).
By their numbers in this assay, from the lowest: compounds 1 and 2 (each within the scatter of the next); then compound 3.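

In this assay the aromatic carbon of the shared core proves able to carry a large change: 3-(dimethylamino)phenoxy gives a 14-fold higher number from compound 2 to compound 3 (1.14 log units; beyond the scatter) when it replaces pentan-3-yl and a 14-fold higher number from compound 1 to compound 3 (1.14 log units; beyond the scatter) when it replaces 4-cyanobenzyl. Compound 1 and compound 2 alone, standing level with two quite different groups at this carbon, gave the impression of a position indifferent to exchange, and compound 3 shows that this does not hold for every group placed there. No measurement at hand accounts for the size of the step.

The entering group differs from both earlier groups in more than one feature, so the compounds shown do not tell whether the step belongs to the ether oxygen, the aromatic ring or the dimethylamino group. A plain phenoxy group without the dimethylamino group, or a 3-(dimethylamino)benzyl group with a methylene carbon in place of the ether oxygen, would separate these parts at the same aromatic carbon.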